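The source may report more compounds than this note shows. Statements on the series, on what has been measured and on what is new or still open speak of the compounds shown alone.

Compound 1, `Cc1cc(NC(=O)Nc2ccccc2C(F)(F)F)c2ccccc2n1`, is one of three ureas that share a common core and differ only in the substituents on the second aromatic ring. Tested in an ADME assay on HepG2 cells (Homo sapiens) for cytotoxicity, with a stated time of 72 h (a higher number here means that more compound is needed for the effect, a lower number that less compound is needed), compound 1 reaches only the assay limit of > 25000 nM, so no number is available for it. Compound 3, `Cc1cc(NC(=O)Nc2cccc(C(C)(C)C)c2)c2ccccc2n1`, likewise gives only the limit of > 25000 nM in this assay. Within the data shown here, compound 2, `Cc1cc(NC(=O)Nc2ccc(Cl)cc2Cl)c2ccccc2n1`, is the single member with a measured number, showing 16000 nM in this assay. Two of the three values therefore sit at the limit, (the limit of > 25000 nM in this assay, at which 2 of the 3 values shown sit), and compound 1 stands among them.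

Compound 4, `COc1ccccc1NC(=O)Nc1cc(C)nc2ccccc12`, has not yet been measured. It differs from compound 1 by methoxy in place of trifluoromethyl on an aromatic carbon. No pair of measured compounds isolates this change, so nothing shown speaks for a step in either direction beyond the usual scatter. In this assay compound 4 is expected to give about 30000 nM, within a range from 15000 nM to 60000 nM. The expected step is a step that the limit leaves unreadable from compound 1 to compound 4, essentially no change, with a fair chance that only a limit is reported again.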

Compound 4, half-maximal effective concentration: > 25000 nM
Compound 4: a limit, no number; the forecaster's own chance of this, stated with the estimate: 65%; the middle value is on the limit's open side.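

Compound 1 and compound 4 both give only a limit in this assay, not a number, so the step between them cannot be read: the limit of > 25000 nM in this assay, at which 3 of the 4 values shown sit.

The compounds shown leave open whether methoxy in place of trifluoromethyl on an aromatic carbon moves the value in this assay in either direction.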